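This account rests on a few compounds, and the source may have more. Where it says the series, first, only, none or still open, it means among the compounds named here.

Three compounds share one core and differ only in the group on an aromatic carbon of the pendant phenyl ring. In a functional assay on MT4 cells (Homo sapiens) for antiproliferative activity, read by MTT assay, with a stated time of 96 h (a higher number here means a weaker inhibitor, a lower number a stronger inhibitor), compound 1 `CCCc1ccc(N2C(=O)NC3(CSC4=C3C(=O)c3ncccc3C4=O)C2=O)cc1` gives 1 nM. Compound 2 `COc1ccc(N2C(=O)NC3(CSC4=C3C(=O)c3ncccc3C4=O)C2=O)cc1` gives 70 nM in this assay. Compound 3 `O=C1C2=C(C(=O)c3ncccc31)C1(CS2)NC(=O)N(c2ccc([N+](=O)[O-])cc2)C1=O` gives 8 nM in this assay. The steps between them are a 70-fold higher number from compound 1 to compound 2 (1.85 log units; beyond the scatter), an 8.0-fold higher number from compound 1 to compound 3 (0.90 log units; beyond the scatter) and an 8.8-fold lower number from compound 2 to compound 3 (0.94 log units; beyond the scatter). Compound 3 therefore stands second highest of the three numbers, closer to compound 1 than to compound 2.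

Compound 4 `O=C1C2=C(C(=O)c3ncccc31)C1(CS2)NC(=O)N(c2ccccc2)C1=O` is the next member: hydrogen in place of nitro on an aromatic carbon. For the measured compounds named here, no measured step removes a substituent to leave hydrogen; every step so far exchanges one group for another at this carbon, and those exchanges span the modest gaps from compound 1 to compound 3 and from compound 2 to compound 3 as well as the large gap from compound 1 to compound 2. The bare ring is expected to land inside that spread rather than outside it, with a modest rise most likely, so for compound 4 the expected step is a 2.5-fold higher number from compound 3 to compound 4 (0.40 log units; beyond the scatter). Compound 4 is estimated at 20 nM in this assay, within 4 nM to 120 nM.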

Compound 4, half-maximal inhibitory concentration: 25 nM
Beside the measured number, compound 4's estimate is 1.3-fold (0.10 log units) below it, within the range that was stated.
By their numbers in this assay, from the lowest: compound 1; then compound 3; then compound 4; then compound 2.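

The bare phenyl ring gives the series a reference point in this assay: taking away nitro produces a 3.1-fold higher number from compound 3 to compound 4 (0.49 log units; beyond the scatter) and taking away propyl produces a 25-fold higher number from compound 1 to compound 4 (1.40 log units; beyond the scatter), so both groups on this aromatic carbon go with a lower number than hydrogen. Taking away methoxy runs the other way, with a 2.8-fold lower number from compound 2 to compound 4 (0.45 log units; beyond the scatter), so this group goes with a higher number than hydrogen. Exchanges alone could not show this: substitution at this carbon moves the number in either direction from hydrogen, and no measurement at hand accounts for the order of the groups.

From the compounds shown here alone, whether a longer chain such as butyl or pentyl continues the trend from hydrogen to propyl remains open. So does the side of hydrogen on which an amine or a carboxylic acid at this carbon would fall.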